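A few compounds are considered here, and "the series" means these few. Any claim that something is new, unique, unknown or untested is made for them only; others in the source may bear on it.

Compound 1 `O=C(Nc1ccc(N=C2NCCN2)cc1)c1ccc(N=C2NCCN2)c(Cl)c1` and compound 2 `O=C(Nc1ccc(N=C2NCCN2)cc1)c1ccc(N=C2NCCN2)c(F)c1` share one core; compound 3 `O=C(Nc1ccc(N=C2NCCN2)c(Cl)c1)c1ccc(N=C2NCCN2)cc1` and compound 4 `O=C(Nc1ccc(N=C2NCCN2)c(F)c1)c1ccc(N=C2NCCN2)cc1` share another, and the difference between the two cores is not broken down here. In an ADME assay on HEK-293T cells (Homo sapiens) for cytotoxicity, read by resazurin assay, with a stated time of 30 h (on this read-out lower numbers stand for higher toxicity in this test and higher numbers for lower toxicity in this test), compound 1 gives > 200000 nM, which is a limit of the assay and not a number. In this assay compound 2 likewise gives only a limit, > 200000 nM. The change from compound 1 to compound 2 is fluoro in place of chloro on an aromatic carbon, and its step that the two limits leave unreadable from compound 1 to compound 2 stays unreadable because of the limit of > 200000 nM in this assay, at which 3 of the 3 values shown sit. Compound 3 in this assay also reaches only a limit, > 200000 nM. The change from compound 3 to compound 4 is fluoro in place of chloro on an aromatic carbon, the same change as from compound 1 to compound 2, at a place described in the same words. The step from compound 3 to compound 4 is expected to be a step that the limit leaves unreadable from compound 3 to compound 4, because of the limit of > 200000 nM in this assay, at which 3 of the 3 values shown sit. Compound 4 is estimated to lie at about 300000 nM in this assay, between 150000 nM and 1000000 nM, most likely again reported only as a limit.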

Compound 4, half-maximal cytotoxic concentration: > 200000 nM
Compound 4 gave a limit, no number; the forecaster's own chance of this, stated with the estimate: 90%; the middle value is on the limit's open side.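

No step can be read between compound 3 and compound 4, because each gives only a limit of the assay and not a number: the limit of > 200000 nM in this assay, at which 4 of the 4 values shown sit.

In this assay the compounds shown leave open at what concentration any of the four turns cytotoxic, and whether fluoro and chloro differ at all on either core.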